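A few compounds are considered here, and "the series" means these few. Any claim that something is new, unique, unknown or untested is made for them only; others in the source may bear on it.

Among the compounds with values here, compound 1 `Cc1cc(=O)n(-c2cccc(F)c2)nc1C(=O)Nc1ccc(Oc2ncnc3[nH]ccc23)cc1` is one of two compounds measured in a functional assay on PC-3 cells (Homo sapiens) for cytotoxicity, read by MTT assay, with a stated time of 72 h (on this read-out lower numbers stand for stronger inhibition and higher numbers for weaker inhibition), where compound 1 gives 14600 nM. Within the data shown here, the only other measured compound, compound 2 `Cc1ccc(-n2nc(C(=O)Nc3ccc(Oc4ncnc5[nH]ccc45)cc3)c(C)cc2=O)cc1`, gives in this assay a value of 9610 nM, and the single step between them, a 1.5-fold lower number from compound 1 to compound 2 (0.18 log units; within the scatter), comes from a change of the aryl group on the aromatic nitrogen. Compound 1 therefore carries the highest of the two numbers, with compound 2 within the scatter of it.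

Compound 3 `Cc1cc(=O)n(-c2cccc(F)c2)nc1C(=O)Nc1ccc(Oc2ncnc3[nH]ccc23)c(F)c1` differs from compound 1 in a different part of the molecule: fluoro in place of hydrogen on an aromatic carbon. Among the measured compounds shown here, no measured step touches this position, so the step of a 1.5-fold lower number from compound 1 to compound 2 (0.18 log units; within the scatter) gives no guidance on the size or direction of the change, and nothing beyond the scatter is expected in this assay. The estimated step of a 1.2-fold lower number from compound 1 to compound 3 (0.09 log units; within the scatter) is expected to be small. Compound 3 is accordingly estimated at 12000 nM, within the range 5000 nM to 35000 nM.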

Compound 3, half-maximal inhibitory concentration: 6680 nM
Compound 3: middle estimate off by 1.8-fold (0.25 log units), on the high side; the measured number falls inside the stated range.
By their numbers in this assay, from the lowest: compounds 3, 2 and 1 (each within the scatter of the next, the first and the last beyond it).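

In this assay, fluoro in place of hydrogen on an aromatic carbon, ortho to a large group and meta to a large group, gives a 2.2-fold lower number from compound 1 to compound 3 (0.34 log units; beyond the scatter), a modest step. It is the first step among the compounds shown that lies beyond the scatter, and it falls in a part of the molecule that the change of aryl group on the aromatic nitrogen does not touch, so this position responds measurably to the addition of a single fluorine atom. No available evidence says why the number falls with this change.

Whether the step is particular to fluoro remains open, since chloro, methoxy and an amine on the same carbon are not among the compounds shown. Also open, from the compounds shown here alone, is whether the step would carry over to the 4-methylphenyl group of compound 2.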